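The source may hold more compounds than are shown below. What is called first, only, known or untested is meant among the compounds shown, and "the series" means these compounds.

Compound 1 `O=C(CCCCc1cn(Cc2ccc3oc(-c4ccccc4)cc(=O)c3c2)nn1)Nc1ccccc1` gives 15600 nM in an assay on isolated protein for inhibition of Amine oxidase [flavin-containing] B (Homo sapiens), read by fluorescence and spectrophotometry; a higher number here means a weaker inhibitor, a lower number a stronger inhibitor. Compound 2 `Cc1ccc(NC(=O)CCc2cn(Cc3ccc4oc(-c5ccccc5)cc(=O)c4c3)nn2)cc1` gives 15600 nM in this assay.

Compound 2 stands level with compound 1: the step of no change at the digits printed from compound 1 to compound 2 (within the scatter) lay within the scatter. Compound 3 `O=C(CCc1cn(Cc2ccc3oc(-c4ccccc4)cc(=O)c3c2)nn1)Nc1ccc(Cl)cc1` differs from compound 2 by chloro in place of methyl on an aromatic carbon, para to a large group. No measured step exchanges these two groups, so the expectation rests on the one step shown, no change at the digits printed from compound 1 to compound 2 (within the scatter), which left the number unchanged. The step to compound 3 is therefore expected to be small, a 1.0-fold lower number from compound 2 to compound 3 (0.02 log units; within the scatter), with no clear direction beyond the scatter. Compound 3 is estimated at 15000 nM, between 6000 nM and 40000 nM.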

Compound 3, half-maximal inhibitory concentration: 15600 nM
Estimate against measurement, compound 3: 1.0-fold (0.02 log units) below, and the stated range covers the measured number.
By their numbers in this assay, from the lowest: compounds 1, 2 and 3 (each within the scatter of the next).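

In this assay, chloro in place of methyl on an aromatic carbon, para to a large group, shows no change at the digits printed from compound 2 to compound 3 (within the scatter) and so adds a second group at this position that reads the same. Putting (4-chlorophenyl)carbamoyl in place of 2-(phenylcarbamoyl)ethyl likewise shows no change at the digits printed from compound 1 to compound 3 (within the scatter) and so gives no separation among the three compounds. Nothing measured here offers a reason for these flat readings.

From the compounds shown here alone, whether an amine, a methoxy group or a carboxylic acid at this position would shift the number remains open.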